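The source may report more compounds than this note shows. Statements on the series, on what has been measured and on what is new or still open speak of the compounds shown alone.

Measured in a functional assay (aorta) for inhibition, with Rattus norvegicus as the target; on this read-out higher numbers stand for weaker inhibition and lower numbers for stronger inhibition:
compound 1 `CCc1nsc(-c2ccc(N3CCN(c4cccc(C(F)(F)F)c4)CC3)nn2)n1`: 8 nM
compound 2 `CN(C)c1nsc(-c2ccc(N3CCN(c4cccc(C(F)(F)F)c4)CC3)nn2)n1`: 0.4 nM; 6 nM (2 entries)
compound 3 `Cc1nsc(-c2ccc(N3CCN(c4cccc(C(F)(F)F)c4)CC3)nn2)n1`: 0.3 nM

Compound 3 has the lower of the two single numbers. The step between those two numbers is large: a 27-fold lower number from compound 1 to compound 3 (1.43 log units; beyond the scatter). Compound 2 has no single number, and its entries lie well apart: the several entries of compound 2 in this assay, 0.4 nM; 6 nM (2 entries).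

Compound 4 `Cc1nsc(-c2ccc(N3CCN(c4cccc(N)c4)CC3)nn2)n1` remains unmeasured. Its difference from the reference compound is amino in place of trifluoromethyl on an aromatic carbon, which is amino in place of trifluoromethyl on an aromatic carbon. Among the compounds with values here, all three measured compounds carry trifluoromethyl there, so no measured step covers this change directly. Within the data shown here, the one measured step is a different edit, hydrogen in place of methyl on a saturated chain carbon bound to an aromatic carbon. It bears on the question only as a sign that a single small edit can move a number in this series a long way.

Compound 3 at 0.3 nM already sits at the low end of the numbers seen, so a higher number is expected rather than a lower one. The expected step in this assay is a 10-fold higher number from compound 3 to compound 4 (1.00 log units; beyond the scatter), a moderate move held with wide uncertainty. Compound 4 is estimated at 3 nM, with an expected range from 0.3 nM to 30 nM.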

Compound 4, half-maximal inhibitory concentration: > 100 nM
Compound 4: a limit, no number (the forecaster's own chance of this, stated with the estimate: 5%); at least 33-fold (1.52 log units) between middle value and limit.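

In this assay, amino in place of trifluoromethyl on this aromatic carbon gives an at least 330-fold higher number from compound 3 to compound 4 (2.52 log units; beyond the scatter), and the size of that step is bounded by a limit rather than fixed by two numbers. The entry for compound 4 is a limit, not a number: the limit of > 100 nM in this assay, at which 1 of the 4 values shown sits.

Within the data shown here, all the earlier compounds carry trifluoromethyl here, so they said nothing about this place on the ring, and it now proves to matter at least as much as the edit behind the one step they offered, a 27-fold lower number from compound 1 to compound 3 (1.43 log units; beyond the scatter).

The compounds shown hold only trifluoromethyl and amino on this carbon, which leaves open where a methoxy, a chlorine or a nitrile would fall, and whether the rise in the number belongs to amino alone or to any loss of trifluoromethyl. The other end of the series also stays unsettled, as compound 2 has no single number to set against compound 3: the several entries of compound 2 in this assay, 0.4 nM; 6 nM (2 entries)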